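A few compounds are considered here, and "the series" means these few. Any claim that something is new, unique, unknown or untested is made for them only; others in the source may bear on it.

Compounds measured so far:
Compound 1 `O=[N+]([O-])c1cn2c(n1)OC[C@@H](NCc1ccc(OC(F)(F)F)cc1F)C2`: 95.6 mL.min-1.g-1
Compound 2 `O=[N+]([O-])c1cn2c(n1)OC[C@@H](NCc1ccc(OC(F)(F)F)cc1Cl)C2`: 69.7 mL.min-1.g-1
Compound 3 `O=[N+]([O-])c1cn2c(n1)OC[C@@H](NCc1ccc(OC(F)(F)F)cc1O)C2`: 96.9 mL.min-1.g-1

These three share one core and differ only in a single group on the aromatic ring. In an in vitro ADME assay on the whole organism (microsomes, liver, Mus musculus) for metabolic stability, read by LC-MS, with a stated time of 24 h, at a dose of 5 mg/kg by the intravenous route (a lower number here means slower removal, a higher number faster removal of the compound), compound 1 gives 95.6 mL.min-1.g-1, compound 2 gives 69.7 mL.min-1.g-1 and compound 3 gives 96.9 mL.min-1.g-1. Compound 3 sits at the top of these three numbers, but the steps of a 1.0-fold higher number from compound 1 to compound 3 (0.01 log units; within the scatter) and a 1.4-fold higher number from compound 2 to compound 3 (0.14 log units; within the scatter) both lie within the scatter, as does a 1.4-fold lower number from compound 1 to compound 2 (0.14 log units; within the scatter); none of the three changes moved the read-out in a way that can be trusted.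

Compound 4 `O=[N+]([O-])c1cn2c(n1)OC[C@@H](NCc1ccc(OC(F)(F)F)cc1OC1CC1)C2` has not yet been measured. It differs from compound 3 in one place: cyclopropyl in place of hydrogen on an oxygen on an aromatic ring. None of the measured steps touches the oxygen of the hydroxy group, so there is no direct precedent for this change among the compounds shown. What the data do show is that swapping fluoro, chloro and hydroxy for one another left the read-out within the scatter each time. On that basis the step of a 1.0-fold higher number from compound 3 to compound 4 (0.01 log units; within the scatter) is expected to stay within the scatter as well, with no direction favoured. Compound 4 is therefore estimated to give 100 mL.min-1.g-1 in this assay, within a range from 50 mL.min-1.g-1 to 200 mL.min-1.g-1.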

Compound 4, intrinsic clearance in microsomes: 151 mL.min-1.g-1
Beside the measured number, compound 4's estimate is 1.5-fold (0.18 log units) below it, within the range that was stated.
By their numbers in this assay, from the lowest: compounds 2, 1, 3 and 4 (each within the scatter of the next, the first and the last beyond it).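

In this assay, within the data shown here, the earlier compounds only exchanged one small group for another on the aromatic carbon, whereas this change adds a cyclopropyl ring on the oxygen of the hydroxy group, and it gives a 1.6-fold higher number from compound 3 to compound 4 (0.19 log units; within the scatter) as its result, so the change on the oxygen alone cannot be trusted to have moved the read-out. A similar picture holds for the cyclopropyloxy group against fluoro, with a 1.6-fold higher number from compound 1 to compound 4 (0.20 log units; within the scatter) as the step, but against chloro the step is a 2.2-fold higher number from compound 2 to compound 4 (0.34 log units; beyond the scatter) and, although modest, it is the only one among these four compounds to clear the scatter, showing that this position can give a real difference in this read-out when compound 2 is the starting point. No separate measurement is available to explain that difference.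

Cyclopropyl is the only carbon group on this oxygen here, so it remains open whether a methyl group or a longer chain there would give a number like that of compound 4. Also open, as far as these compounds go, is how an amine or a carboxylic acid would read at the same place on the ring.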